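Moving the ether oxygen along the chain of compound 2

A few compounds are considered here, and "the series" means these few. Any claim that something is new, unique, unknown or untested is made for them only; others in the source may bear on it.

In a functional assay on NCI-H322 cells (Homo sapiens) for antiproliferative activity (a lower number here means a stronger inhibitor of growth, a higher number a weaker inhibitor of growth), compound 2 (`COCCCCCCCCCCC/C=C1\CC(CO)(COC(=O)C(C)(C)C)OC1=O`) gives > 10 ug/mL, which is a limit and not a number. Compound 1 (`COCCCCCCCCCCCCCCC/C=C1/CC(CO)(COC(=O)C(C)(C)C)OC1=O`) gives > 10 ug/mL, also a limit. Compound 3 (`CCCCCCCCC(O)CCCCCC/C=C1\CC(CO)(COC(=O)C(C)(C)C)OC1=O`) gives > 10 ug/mL, again a limit. All three therefore stand together at the limit of > 10 ug/mL in this assay, at which 3 of the 3 values shown sit. Among the measured compounds shown here, the one measured step that bears on this series is a step that the two limits leave unreadable from compound 2 to compound 3, so it offers no size to carry forward. Compound 4 (`CCCCCOCCCCCCC/C=C1\CC(CO)(COC(=O)C(C)(C)C)OC1=O`) carries pentyloxy in place of 4-methoxybutyl on a saturated chain carbon, seven bonds along the chain from a double-bonded chain carbon. No shift beyond the scatter is expected in this assay, and the expected move is a step that the limit leaves unreadable from compound 2 to compound 4. Compound 4 is expected at 15 ug/mL, with an estimated range of 7 ug/mL to 40 ug/mL.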

Compound 4, concentration for 50% growth inhibition: 9.52 ug/mL
Estimate against measurement, compound 4: 1.6-fold (0.20 log units) above; the measured number falls inside the stated range.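

Among the compounds shown here, compound 4 is the first to give a number rather than a limit in this assay, so the ether oxygen's place in the chain can now be tied to a reading. Pentyloxy in place of 4-methoxybutyl gives an at least 1.0-fold lower number from compound 2 to compound 4 (0.02 log units; that floor lies within the scatter), and (pentyloxy)methyl in place of 1-hydroxynonyl gives an at least 1.0-fold lower number from compound 3 to compound 4 (0.02 log units; that floor lies within the scatter). The rest of the series stays at the limit: the limit of > 10 ug/mL in this assay, at which 3 of the 4 values shown sit.

As far as these compounds go, the true size of both steps remains open. So does whether an amine in place of the ether oxygen, or a longer chain after it, would give a lower number.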